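Methylcarbamoyl on compound 2: a step from the limit

A few compounds are considered here, and "the series" means these few. Any claim that something is new, unique, unknown or untested is made for them only; others in the source may bear on it.

In an ADME assay on H1-HeLa cells (Homo sapiens) for cytotoxicity, read by MTT assay, with a stated time of 3 days (on this read-out lower numbers stand for higher toxicity in this test and higher numbers for lower toxicity in this test), compound 1 `CCOC(=O)c1cc2ccc(Oc3ccccc3)cc2s1` gives > 100000 nM, which is a limit. Compound 2 `CCOC(=O)c1sc2cc(Oc3ccccc3)ccc2c1C` gives > 100000 nM, also a limit. Going by the values given here, the series so far shows (the limit of > 100000 nM in this assay, at which 2 of the 2 values shown sit). Among the compounds with values here, the only measured step is a step that the two limits leave unreadable from compound 1 to compound 2, so it offers no size to carry forward. Compound 3 `CCOC(=O)c1sc2cc(Oc3cccc(C(=O)NC)c3)ccc2c1C` has methylcarbamoyl in place of hydrogen on an aromatic carbon, meta to a large group: methylcarbamoyl in place of hydrogen on an aromatic carbon. With no readable step to draw on, no change beyond the scatter is expected in this assay, and the expected step is a number no higher from compound 2 to compound 3 (the limit leaves the size open). Compound 3 is estimated at 100000 nM, with an expected range of 30000 nM to 200000 nM.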

Compound 3, half-maximal cytotoxic concentration: 5100 nM
For compound 3 the middle estimate is 20-fold (1.29 log units) above the measured one; measured number outside the range, below it.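

In this assay, going by these compounds alone, methylcarbamoyl in place of hydrogen on an aromatic carbon, meta to a large group, gives an at least 19-fold lower number from compound 2 to compound 3 (1.29 log units; beyond the scatter), the first readable step, toward higher toxicity in this test. The step from compound 1 to compound 2 cannot be read, so this six-membered aromatic ring of carbon only is the first place shown where a change moves the read-out off the limit.

Going by these compounds, whether a carboxylic acid or an amine at the same place would act alike remains open. Also open, on these data alone, is whether methylcarbamoyl elsewhere on this ring would give a similar step.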